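This account rests on a few compounds, and the source may have more. Where it says the series, first, only, none or still open, it means among the compounds named here.

Measured in a functional assay on HeLa cells (Homo sapiens) for cytotoxicity, read by MTT assay; a lower number here means a stronger inhibitor, a higher number a weaker inhibitor:
Compound 1 `CCOC(=O)C12C(=O)OCC=C1COC2c1ccccc1` gives 12800 nM.
Compound 2 `CCOC(=O)C12C(=O)OCC=C1COC2c1ccc(C(C)(C)C)cc1` gives 25400 nM.
Compound 3 `CCOC(=O)C12C(=O)OCC=C1COC2c1ccc(OC)c(OC)c1` gives 10000 nM.

Compound 2 stands at the largest number of the three in this assay; the gap to compound 3 lies beyond the scatter, while compound 1 sits within the scatter of it, so no order between those two can be read. Among the compounds with values here, the step of a 2.0-fold higher number from compound 1 to compound 2 (0.30 log units; within the scatter) is the only measured step on the shared core, and it was within the scatter. Compound 4 `CCOC(=O)C12C(=O)OCC=C1COC2c1ccc([N+](=O)[O-])cc1` carries the change (nitro in place of tert-butyl on an aromatic carbon). Within the data shown here, no measured pair shows a nitro group on this core, so the step bearing on it is only the tert-butyl step from compound 1 to compound 2, which gives little guidance beyond suggesting that a change at this aromatic carbon need not move the number much. Compound 4 is therefore expected to land near compound 2, with the step of a 1.8-fold lower number from compound 2 to compound 4 (0.26 log units; within the scatter) estimated as small. The estimated value for compound 4 is 14000 nM, with a range from 5000 nM to 40000 nM.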

Compound 4, half-maximal inhibitory concentration: 53400 nM
Beside the measured number, compound 4's estimate is 3.8-fold (0.58 log units) below it; the whole stated range lies below it.
By their numbers in this assay, from the lowest: compounds 3, 1 and 2 (each within the scatter of the next, the first and the last beyond it); then compound 4.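

In this assay the aromatic carbon carrying the substituent now gives a step that can be read: nitro in place of tert-butyl gives a 2.1-fold higher number from compound 2 to compound 4 (0.32 log units; beyond the scatter), and nitro in place of hydrogen gives a 4.2-fold higher number from compound 1 to compound 4 (0.62 log units; beyond the scatter). Within the data shown here, the earlier tert-butyl step stayed within the scatter, so the nitro group is the first change to show that a substituent at this carbon can move the number, and it moves it towards weaker inhibition. Nothing measured here accounts for this shift.

Whether the shift is particular to nitro remains open, since an amine, a carboxylic acid or a single chlorine atom at this same carbon does not appear among these compounds. As far as these compounds go, it is also open whether any group at this carbon could bring the number lower than the unsubstituted phenyl of compound 1.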